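Trifluoromethyl in Place of Nitro: An Expected Limit

The source may report more compounds than this note shows. Statements on the series, on what has been measured and on what is new or still open speak of the compounds shown alone.

Compound 3 `CC(C)n1ncc2c(C(=O)NCc3cn(-c4ccc([N+](=O)[O-])cc4)nn3)cccc21` is one of three closely related amides tested in a functional assay on MGC-803 cells (Homo sapiens) for inhibition, read by MTT assay, with a stated time of 72 h; a lower number here means a stronger inhibitor, a higher number a weaker inhibitor. In this assay compound 3 gives only a limit, > 40000 nM. Compound 1 `Cc1ccc(-n2cc(CNC(=O)c3cccc4c3cnn4C(C)C)nn2)cc1C` likewise gives only a limit in this assay, > 40000 nM. Compound 2 `CC(C)n1ncc2c(C(=O)NCc3cn(-c4ccc(I)cc4)nn3)cccc21` also returns a limit in this assay, > 40000 nM. The steps among them, a step that the two limits leave unreadable from compound 1 to compound 2, a step that the two limits leave unreadable from compound 1 to compound 3 and a step that the two limits leave unreadable from compound 2 to compound 3, cannot be read in size because of the limit of > 40000 nM in this assay, at which 3 of the 3 values shown sit. Compound 3 therefore stands at the same limit as its two neighbours, with no number that would rank it.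

Compound 4 `CC(C)n1ncc2c(C(=O)NCc3cn(-c4ccc(C(F)(F)F)cc4)nn3)cccc21` differs from compound 3 by trifluoromethyl in place of nitro on an aromatic carbon. The three unreadable steps bear on this change only in that every group so far placed on that phenyl ring, dimethyl, iodo and nitro, left the amide at the limit in this assay; they give no direction or size for the new step. The step is accordingly expected to be none beyond the scatter, a step that the limit leaves unreadable from compound 3 to compound 4. Compound 4 is expected to give about 60000 nM in this assay, within a range from 20000 nM to 200000 nM, and most probably reported as a limit again.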

Compound 4, half-maximal inhibitory concentration: > 40000 nM
Compound 4: a limit, no number; the forecaster's own chance of this, stated with the estimate: 80%; the middle value does not contradict the limit.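

The new steps joining compound 4 to compound 1, compound 2 and compound 3 cannot be read in size, because all four compounds stand at one limit: the limit of > 40000 nM in this assay, at which 4 of the 4 values shown sit.

The compounds shown leave open what number any of the four would give, and whether any group on that phenyl ring gives a readable value.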